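The source may hold more compounds than are shown below. What is called first, only, known or untested is meant among the compounds shown, and "the series" means these compounds.

Compound 1 `CN1CCN(CCNCc2cn(-c3ccc(F)cc3F)nc2-c2ccc(S(=O)(=O)N(C)C)cc2)CC1`: > 20000 nM
Compound 2 `Cc1ccccc1-c1nn(-c2ccc(OC(F)(F)F)cc2)cc1CNCCN1CCN(C)CC1`: 17000 nM

In an ADME assay on Huh-7 cells (Homo sapiens) for cytotoxicity (a lower number here means that less compound is tolerated, a higher number that more compound is tolerated), compound 1 reaches only a limit of the assay, not a number: > 20000 nM, which is the limit of > 20000 nM in this assay, at which 1 of the 2 values shown sits. Compound 2 gives 17000 nM in this assay. Compound 3 `CN1CCN(CCNCc2cn(-c3ccc(F)cc3F)nc2C(C)(C)C)CC1` has not been measured yet. It differs from compound 1 by tert-butyl in place of 4-(dimethylsulfamoyl)phenyl on an aromatic carbon. Among the measured compounds shown here, no measured pair of compounds differs in a single place, so no step has been seen, and the step of a number no higher from compound 1 to compound 3 (the limit leaves the size open) is expected to remain within the usual scatter. Compound 3 is therefore expected to give 20000 nM, in a range from 8000 nM to 40000 nM.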

Compound 3, half-maximal cytotoxic concentration: > 20000 nM
Compound 3: only a limit was reported; the forecaster's own chance of this, stated with the estimate: 50%; the middle value sits exactly at the limit.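

Compound 1 and compound 3 both give only a limit in this assay, not a number, so no step between them can be read: the limit of > 20000 nM in this assay, at which 2 of the 3 values shown sit.

The compounds shown leave open whether swapping 4-(dimethylsulfamoyl)phenyl for tert-butyl changes how much compound is tolerated.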